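The source may report more compounds than this note shows. Statements on the series, on what has been measured and on what is new or still open speak of the compounds shown alone.

Working notes on the series. In an assay on isolated protein for inhibition of Amine oxidase [flavin-containing] A (Homo sapiens), read by spectrophotometry (on this read-out lower numbers stand for stronger inhibition and higher numbers for weaker inhibition), compound 2 `CN(C)c1ccc(/C=N/Nc2nc3ccccc3nc2Cc2ccccc2)cc1` gives 83 nM; compound 1 `COc1ccc(/C=N/Nc2nc3ccccc3nc2Cc2ccccc2)cc1OC` gives 56 nM, and a 1.5-fold higher number from compound 1 to compound 2 (0.17 log units; within the scatter), so the two numbers sit together. Compound 3 `Brc1cccc(/C=N/Nc2nc3ccccc3nc2Cc2ccccc2)c1` differs from compound 2 by 3-bromophenyl in place of 4-(dimethylamino)phenyl on a carbon with a double bond to nitrogen. Among the compounds with values here, the only step measured at this place is the exchange of aryl groups from compound 1 to compound 2, which stayed within the scatter. For compound 3 the expected step in this assay is therefore none beyond the scatter, a 1.1-fold higher number from compound 2 to compound 3 (0.04 log units; within the scatter). Compound 3 is estimated at 90 nM, in the range 40 nM to 250 nM.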

Compound 3, half-maximal inhibitory concentration: 9.8 nM
Estimate against measurement, compound 3: 9.2-fold (0.96 log units) above; measured number below the stated range.
By their numbers in this assay, from the lowest: compound 3; then compounds 1 and 2 (each within the scatter of the next).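

The position on the carbon with a double bond to nitrogen is not indifferent to the aryl group in this assay: 3-bromophenyl gives a clear gain over both earlier groups (an 8.5-fold lower number from compound 2 to compound 3 (0.93 log units; beyond the scatter); a 5.7-fold lower number from compound 1 to compound 3 (0.76 log units; beyond the scatter)). Compound 1 and compound 2 had suggested no such sensitivity. Nothing at hand explains this gain.

The compounds shown do not separate the contribution of the bromine from that of the ring carrying it. A plain phenyl, or a chlorine or nitrile in place of the bromine, would bear on this.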